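Fluoro for Chloro on the Shared Core of Compound 1

The source may report more compounds than this note shows. Statements on the series, on what has been measured and on what is new or still open speak of the compounds shown alone.

Measured compounds:
- compound 1 `O=S(=O)(c1cccc(F)c1)c1cn(C2CCNC2)c2ccc(Cl)cc12`: "not determined" (no result reported)
- compound 2 `O=S(=O)(c1cccc(F)c1)c1cn(C2CCNC2)c2cccc(F)c12`: "not determined" (no result reported)
- compound 3 `CN1CCC(n2cc(S(=O)(=O)c3cccc(F)c3)c3ccccc32)C1`: 49%

Going by the values given here, in a functional assay on HeLa cells for agonist activity at 5-hydroxytryptamine receptor 6 (Homo sapiens), read by cAMP accumulation and immunoassay, with a stated time of 10 min (on this read-out higher numbers stand for larger maximal responses and lower numbers for smaller maximal responses), compound 1 has no number, its entry being "not determined" (no result reported), and compound 2 likewise has none, its entry being "not determined" (no result reported); the only number comes from compound 3, which gives 49%. Compound 4 `O=S(=O)(c1cccc(F)c1)c1cn(C2CCNC2)c2ccc(F)cc12` is the next compound to be tested. It differs from compound 1 in one place: fluoro in place of chloro on an aromatic carbon. With no number for compound 1, the size of this step cannot be read from the data; in this assay a change of roughly the size of the usual scatter is expected, in no particular direction. For compound 4 in this assay an estimated value of 50% is expected, within a range from 20% to 85%, resting on compound 3 with 49%.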

Compound 4, largest response reached (Emax), in percent of the reference or control that the assay uses: 50%
Estimate against measurement, compound 4: no gap at the digits printed; the range from low to high includes it.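

Compound 1 has no number in this assay, so the step to compound 4 cannot be read. On these data alone, how fluoro in place of chloro changes the maximal response stays open. No further data here bear on this result.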